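Para-halogen swap on the aryl semicarbazide of compound 1

A few compounds are considered here, and "the series" means these few. Any claim that something is new, unique, unknown or untested is made for them only; others in the source may bear on it.

In a functional assay on CCRF-CEM cells (Homo sapiens) for inhibition, read by MTT assay, with a stated time of 72 h (a higher number here means a weaker inhibitor, a lower number a stronger inhibitor), compound 1 `COc1cc(NC(C)CCCNC(=O)NNC(=O)Nc2ccc(Br)cc2)c2ncccc2c1` gives 110000 nM, the highest of the two numbers in hand. Among the compounds with values here, compound 2 `COc1cc(NC(C)CCCNC(=O)Nc2ccc(O)cc2)c2ncccc2c1` gives 23000 nM in this assay; the only measured step, a 4.8-fold lower number from compound 1 to compound 2 (0.68 log units; beyond the scatter), replaces the whole aryl semicarbazide end and so does not speak to a change of halogen. Compound 3 `COc1cc(NC(C)CCCNC(=O)NNC(=O)Nc2ccc(F)cc2)c2ncccc2c1` differs from compound 1 by fluoro in place of bromo on an aromatic carbon. With no halogen comparison among the measured compounds, no step beyond the scatter is expected in this assay. Compound 3 is estimated at 130000 nM, between 50000 nM and 350000 nM, an expected 1.2-fold higher number from compound 1 to compound 3 (0.07 log units; within the scatter).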

Compound 3, half-maximal inhibitory concentration: 118000 nM
Estimate against measurement, compound 3: 1.1-fold (0.04 log units) above, within the range that was stated.
By their numbers in this assay, from the lowest: compound 2; then compounds 1 and 3 (each within the scatter of the next).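

Fluoro in place of bromo on this aromatic carbon gives no readable change in this assay: a 1.1-fold higher number from compound 1 to compound 3 (0.03 log units; within the scatter). The gap to the 4-hydroxyphenyl end persists with fluoro, at a 5.1-fold higher number from compound 2 to compound 3 (0.71 log units; beyond the scatter), so it does not depend on which of these two halogens is present. No evidence on the cause of either result is available.

From the compounds shown here alone, whether a methoxy group or an amine on this carbon would leave the number unchanged stays open. Also open, going by these compounds, is which part of the replaced end carries the gap to compound 2, since that step changes more than the aromatic substituent.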